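The compounds below may be only part of what the source reports. "The series", "measured", "known", "first", "only" and "open" are said of these compounds alone.

Measured so far in an assay on isolated protein for inhibition of long-chain fatty acid transport protein 1 (Homo sapiens); a lower number here means a stronger inhibitor, a higher number a weaker inhibitor:
Compound 1 `CCn1nnc(-c2ccc(NC(=O)CSc3nnc(CNc4ccccc4)n3CC)cc2)n1` gives > 1000 nM, a limit of the assay.
Compound 2 `CCc1ccc2oc(CSc3nnc(CNc4ccccc4)n3CC)nc2c1` gives > 1000 nM, also a limit of the assay.
Compound 3 `CCC(=O)c1ccc2nc(CSc3nnc(CNc4ccccc4)n3CC)oc2c1` gives 900 nM.

Compound 2 thus stands at the limit of > 1000 nM in this assay, at which 2 of the 3 values shown sit, and no number is known for it; compound 3, which carries a carbonyl-bearing group where compound 2 carries ethyl, sits with a value close to that limit.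

Compound 4 `CC/C(=N/O)c1ccc2oc(CSc3nnc(CNc4ccccc4)n3CC)nc2c1` has not yet been measured in this assay. Its change from compound 2 is a group of 5 heavy atoms (3 carbon, 1 nitrogen, 1 oxygen; no ring) in place of a group of 2 heavy atoms (2 carbon; no ring), on an aromatic carbon.

For the measured compounds named here, no measured step bridges this kind of change, so nothing fixes its size. Going by the values given here, the only anchor is compound 3, whose value of 900 nM shows that a larger polar group in this place is compatible with weak but measurable inhibition. On that basis compound 4 is expected to land near the limit, with a step from compound 2 of an at least 1.2-fold lower number from compound 2 to compound 4 (0.09 log units; that floor lies within the scatter) at most, and nothing beyond the scatter would surprise. The estimate for compound 4 is 800 nM, with a range from 250 nM to 3000 nM.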

Compound 4, half-maximal inhibitory concentration: 260 nM
Estimate against measurement, compound 4: 3.1-fold (0.49 log units) above; the measured number falls inside the stated range.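

In this assay, putting the group of compound 4 in place of ethyl on this aromatic carbon gives an at least 3.8-fold lower number from compound 2 to compound 4 (0.58 log units; beyond the scatter), so a change at this position can move the series beyond the scatter. This step is a bound and not a size, because compound 2 is only a limit: the limit of > 1000 nM in this assay, at which 2 of the 4 values shown sit. The entering group is larger than ethyl and, unlike ethyl, counts a hydrogen-bond donor and hydrogen-bond acceptors, so this position accepts more than a small alkyl group without a loss of inhibition.

Compound 2 and compound 4 do not separate the effect of size from that of the donor or acceptors in the entering group. As far as these compounds go, how an amine, a carboxylic acid or a longer chain on this aromatic carbon would compare remains open.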